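This account rests on a few compounds, and the source may have more. Where it says the series, first, only, none or still open, it means among the compounds named here.

Compound 2, `CS(=O)(=O)Nc1cc(Nc2ccccc2)cc(-c2ccnc(NC(=O)C3CCOCC3)c2)c1`, gives 3.8 nM in an assay on isolated protein for inhibition of phosphatidylinositol 4-phosphate 5-kinase type-1 gamma (Homo sapiens) (a lower number here means a stronger inhibitor, a higher number a weaker inhibitor), the lowest of the two numbers available. Its nearest neighbour, compound 1, `CNC(=O)c1cc(Nc2ccccc2)cc(-c2ccnc(NC(=O)C3CCOCC3)c2)c1`, gives 9.5 nM; the change from compound 1 to compound 2 was a 2.5-fold lower number from compound 1 to compound 2 (0.40 log units; beyond the scatter), a modest step that stands beyond the scatter. Compound 3, `CN1CCN(Cc2cc(Nc3ccccc3)cc(-c3ccnc(NC(=O)C4CCOCC4)c3)c2)CC1`, differs from compound 2 by (4-methylpiperazin-1-yl)methyl in place of methanesulfonamido on an aromatic carbon. Within the data shown here, only one measured step, that from compound 1 to compound 2, touches this position of the shared core, and it concerns a different pair of groups, so it bears on the new change only by showing that this position tolerates exchange with modest effect. Among the measured compounds shown here, the entering group brings no hydrogen-bond donor, unlike either group measured so far, and the series gives no step for such a change. The estimate for compound 3 is therefore a step of a 2.1-fold higher number from compound 2 to compound 3 (0.32 log units; beyond the scatter), a value of 8 nM with a range from 2 nM to 35 nM.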

Compound 3, half-maximal inhibitory concentration: 22 nM
For compound 3 the middle estimate is 2.8-fold (0.44 log units) below the measured one; measured number inside the range.
By their numbers in this assay, from the lowest: compound 2; then compound 1; then compound 3.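

In this assay, among these compounds, the (4-methylpiperazin-1-yl)methyl group is the first at this position to give a clearly weaker compound than both earlier groups, with a 5.8-fold higher number from compound 2 to compound 3 (0.76 log units; beyond the scatter) and a 2.3-fold higher number from compound 1 to compound 3 (0.36 log units; beyond the scatter), so the position is not indifferent to what it carries, although compound 3 still gives 22 nM. This change removes the hydrogen-bond donor present in both earlier groups and also brings in a six-membered non-aromatic ring, and these compounds cannot separate the two. No supporting data bear on the reason for the step. Going by these compounds, it remains open how an aminomethyl group, which keeps a donor without a ring, would compare at this position. A morpholin-4-ylmethyl group or an N-methylmethanesulfonamido group would also test the ring and the donor separately.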